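One Acidic Ring Head for Another on a Shared Core

The source may hold more compounds than are shown below. What is called first, only, known or untested is meant among the compounds shown, and "the series" means these compounds.

Among the measured compounds shown here, compound 1 `CC(C)[C@@H](c1ccc(-c2ccc3cccc(F)c3c2)[nH]c1=O)[C@H]1OC(=O)NC1=O` is the only compound here with a measured number. In a functional assay on CHO cells for antagonist activity at prostaglandin E2 receptor EP3 subtype (Homo sapiens), read by cAMP accumulation, with a stated time of 30 min (on this read-out higher numbers stand for weaker inhibition and lower numbers for stronger inhibition), compound 1 gives 92 nM. Compound 2 `CCC(/C=C1\OC(=O)NC1=O)(CC)c1ccc(-c2ccc3c(c2)OC(C)(C)CC3)[nH]c1=O` stands apart: in this assay compound 2 gives > 20000 nM, and that is a limit of the assay, not a number. So compound 1 holds the one real value shown, and no two measured compounds differ in a single place, which leaves no measured step to lean on.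

Compound 3 `CC(C)[C@H](C[C@H]1SC(=O)NC1=O)c1ccc(-c2ccc3cccc(F)c3c2)[nH]c1=O` has not yet been measured. It differs from compound 1 in one place: (2,4-dioxo-1,3-thiazolidin-5-yl)methyl in place of 2,4-dioxo-1,3-oxazolidin-5-yl on a saturated chain carbon bound to an aromatic carbon and a saturated chain carbon. With nothing measured for a change of this kind, the expectation rests on compound 1 alone, and a modest weakening in this assay is expected rather than a large one. Compound 3 is therefore expected to give 250 nM in this assay, with a range from 50 nM to 1500 nM. That estimate means a step of a 2.7-fold higher number from compound 1 to compound 3 (0.43 log units; beyond the scatter).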

Compound 3, half-maximal inhibitory concentration: 9 nM
Beside the measured number, compound 3's estimate is 28-fold (1.44 log units) above it; the whole stated range lies above it.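

In this assay, placing (2,4-dioxo-1,3-thiazolidin-5-yl)methyl where compound 1 carries 2,4-dioxo-1,3-oxazolidin-5-yl gives a 10-fold lower number from compound 1 to compound 3 (1.01 log units; beyond the scatter), and a lower number here means stronger inhibition. This shows that the group on this saturated chain carbon can be exchanged without losing activity, and that such an exchange can change the result by a large step, well beyond the usual scatter. Nothing shown here explains why this step is so large.

The change alters two things at once, the ring and the added methyl link, so the compounds shown cannot say which of them matters, or whether both do. Also open, on these data alone, is how 2,4-dioxo-1,3-thiazolidin-5-yl joined directly to the chain, or a carboxylic acid at this place, would compare.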